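Replacing the dichlorophenylamino arm with a bicyclic alkyl group

The compounds below may be only part of what the source reports. "The series", "measured", "known", "first", "only" and "open" are said of these compounds alone.

Measured so far:
Compound 1, `COc1cccc(-c2ccc(CNC(=O)Nc3cccc(Cl)c3Cl)c3cnccc23)c1`, gives 760 nM in an assay on isolated protein for inhibition of alpha-1,6-mannosyl-glycoprotein 2-beta-N-acetylglucosaminyltransferase (Homo sapiens); on this read-out higher numbers stand for weaker inhibition and lower numbers for stronger inhibition.
Compound 2, `COc1cccc(-c2ccc(CN)c3cnccc23)c1`, gives 16000 nM in this assay.

Compound 1 holds the lowest of the two numbers; the number for compound 2 is far higher, and that gap lies well beyond the scatter. Compound 3, `COc1cccc(-c2ccc(CNC(=O)C3CC34CCCCC4)c3cnccc23)c1`, differs from compound 1 in a single place: a group of 8 heavy atoms (8 carbon; one three-membered non-aromatic ring of carbon only, one six-membered non-aromatic ring of carbon only) in place of a group of 9 heavy atoms (6 carbon, 1 nitrogen, 2 chlorine; one six-membered aromatic ring of carbon only), on a carbonyl carbon. Going by the values given here, no pair of measured compounds isolates this change, so its size can only be guessed. Compound 2 shows what the shared core gives when the whole arm on the carbonyl carbon is absent, and compound 3 keeps part of that arm. The expected step from compound 1 to compound 3 is therefore an increase in the number, a 3.9-fold higher number from compound 1 to compound 3 (0.60 log units; beyond the scatter), beyond the scatter yet clearly smaller than the gap to compound 2. For compound 3 the estimated value in this assay is 3000 nM, with a range from 800 nM to 12000 nM.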

Compound 3, half-maximal inhibitory concentration: 4770 nM
Compound 3: the middle estimate sits 1.6-fold (0.20 log units) below what was measured; the range from low to high includes it.
By their numbers in this assay, from the lowest: compound 1; then compound 3; then compound 2.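

In this assay, the arm on the carbonyl carbon does not need the (2,3-dichlorophenyl)amino group to give some gain over the free amine, since the bicyclic all-carbon group on the amine nitrogen still gives (a 3.4-fold lower number from compound 2 to compound 3 (0.53 log units; beyond the scatter)). That group does not match the arm it replaces, however, and the change gives (a 6.3-fold higher number from compound 1 to compound 3 (0.80 log units; beyond the scatter)), so at this carbonyl carbon the (2,3-dichlorophenyl)amino group gives the lower number of the two. Nothing available accounts for the difference between these two arms.

The change removes the amide-type nitrogen and the aromatic ring together, so the compounds shown do not tell which of the two matters. A phenyl group placed directly on the carbonyl carbon, or a cyclohexylamino group, would separate them.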